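Methyl for methoxy on an inactive thiophene series

The source may report more compounds than this note shows. Statements on the series, on what has been measured and on what is new or still open speak of the compounds shown alone.

The shared core of compound 1 `COc1ccc(C(=O)c2sc(Nc3ccc(C)cc3)c(C(=O)O)c2C)cc1` carries an acid and an anilino group, and in a functional assay, with a stated time of 150 min, tested at 25 ug/mL (a lower number here means a weaker effect, a higher number a stronger effect of the compound at the concentration tested), compound 1 is reported as "not active" (no number reported). Compound 2 `COc1ccc(C(=O)c2sc(Nc3ccc(F)cc3)c(C(=O)O)c2C)cc1` gives 0.836% in this assay. Compound 3 `COc1ccc(C(=O)c2sc(Nc3ccc(Cl)cc3)c(C(=O)O)c2C)cc1` is again reported as "not active" (no number reported) in this assay, so no single number stands for it, and nothing in the three results rises clearly out of the scatter. Compound 4 `Cc1ccc(C(=O)c2sc(Nc3ccc(Cl)cc3)c(C(=O)O)c2C)cc1` differs from compound 3 by methyl in place of methoxy on an aromatic carbon. Among the compounds with values here, no measured pair shows this change, so no step can be read; in this assay the account expects no step beyond the scatter. Compound 4 is therefore estimated at 1%, within 0% to 8%, in this assay.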

Compound 4, a percentage reported as activity, at one concentration (the size of the read-out at that concentration, not a potency): "not active" (no number reported)
The entry for compound 4 holds no number; no gap can be computed for the estimate.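

Compound 3 and compound 4 both lack a number in this assay, so no step can be read between them. No measurement shown offers an explanation for this result. The compounds shown leave open whether 4-methoxyphenyl to 4-methylphenyl changes the read-out in any compound with a measurable effect.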